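Trading an Allyl for a Bromo on the Biaryl Core

This account rests on a few compounds, and the source may have more. Where it says the series, first, only, none or still open, it means among the compounds named here.

Measured so far:
Compound 1 `C=CCc1cc(C(=O)N[C@H](C)CCCc2cccnc2)ccc1-c1ccc(OC)c(OC)c1`: 80 nM
Compound 2 `COc1cccc(-c2ccc(C(=O)NCCCCc3cccnc3)cc2)c1`: 280 nM
Compound 3 `Cc1cccc(-c2ccc(C(=O)NCCCCc3cccnc3)cc2)c1`: 500 nM

In an assay (Canis lupus familiaris) for binding affinity to platelet-activating factor receptor (Homo sapiens), read by radioligand binding (a higher number here means a weaker inhibitor, a lower number a stronger inhibitor), compound 1 gives 80 nM, the lowest of the three numbers and therefore the strongest inhibitor here. Compound 2 gives 280 nM and compound 3 gives 500 nM; both of those stand beyond the scatter from compound 1. Within the data shown here, the one step between measured compounds that differ in a single place, a 1.8-fold higher number from compound 2 to compound 3 (0.25 log units; within the scatter), concerns a methyl in place of a methoxy on an aromatic carbon and stays within the scatter.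

Compound 4 `COc1ccc(-c2ccc(C(=O)N[C@H](C)CCCc3cccnc3)cc2Br)cc1OC` has not yet been measured. It differs from compound 1 in one place: bromo in place of allyl on an aromatic carbon. The change sits ortho to a 3,4-dimethoxyphenyl group on the shared core. Among the measured compounds shown here, no measured step touches this position or this kind of exchange, so the data give no direction to expect. The expected step of a 1.5-fold higher number from compound 1 to compound 4 (0.18 log units; within the scatter) is therefore small, with the range open in both directions. For compound 4 the estimate in this assay is 120 nM, expected to lie between 40 nM and 400 nM.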

Compound 4, half-maximal inhibitory concentration: 180 nM
For compound 4 the middle estimate is 1.5-fold (0.18 log units) below the measured one, within the range that was stated.
By their numbers in this assay, from the lowest: compound 1; then compounds 4, 2 and 3 (each within the scatter of the next, the first and the last beyond it).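

In this assay, exchanging allyl for bromo on this aromatic carbon, ortho to a 3,4-dimethoxyphenyl group, gives a 2.3-fold higher number from compound 1 to compound 4 (0.35 log units; beyond the scatter). Among these compounds, this is a modest step, but it lies beyond the scatter, and it is the first measured sign that what sits at this position can shift the number. The allyl group, with 3 carbon atoms and a double bond, gives the stronger inhibitor here than the single bromine atom, but no measurement shown explains the difference.

On these data alone, whether a propyl chain, which has three carbons and no double bond, would behave like allyl remains open, as does the effect of an amine or a carboxylic acid on this carbon. This single pair also cannot show whether the same exchange would give a similar step on another core.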